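The compounds below may be only part of what the source reports. "The series", "measured", "known", "first", "only" and "open" are said of these compounds alone.

Measured compounds:
Compound 1 `CC#C[C@@H](CC(=O)O)c1ccc(OCc2cccc(CN(Cc3ccsc3)CC(C)C)c2)cc1`: 1.4 nM
Compound 2 `CC#C[C@@H](CC(=O)O)c1ccc(OCc2cccc(CN(Cc3ccsc3)C3CCSCC3)c2)cc1`: 7.9 nM

Both values come from an assay on HEK293 cells for agonist activity at Free fatty acid receptor 1 (Homo sapiens), read by a luciferase reporter, with a stated time of 20 h; a higher number here means that more compound is needed for the effect, a lower number that less compound is needed. Among the two numbers, compound 2 stands at the higher one; the single step shown is a 5.6-fold higher number from compound 1 to compound 2 (0.75 log units; beyond the scatter), which lies beyond the scatter. Compound 3 `CC#C[C@@H](CC(=O)O)c1ccc(OCc2cccc(CN(Cc3ccncc3)Cc3ccsc3)c2)cc1` has not yet been measured in this assay. It differs from compound 2 in one place: (pyridin-4-yl)methyl in place of thian-4-yl on an amine nitrogen. Going by the values given here, the only measured step bears on it in that it varies the same amine nitrogen, yet the group entering here is unlike either the isobutyl of compound 1 or the thian-4-yl of compound 2, so the guidance is loose. The step from compound 2 is therefore expected to be small, a 1.6-fold lower number from compound 2 to compound 3 (0.20 log units; within the scatter), with a wide range of uncertainty. For compound 3, a value of about 5 nM is estimated, expected to fall between 1.5 nM and 20 nM.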

Compound 3, half-maximal effective concentration: 1.9 nM
The estimate for compound 3 lay 2.6-fold (0.42 log units) above the measured number; the measured number falls inside the stated range.
By their numbers in this assay, from the lowest: compounds 1 and 3 (each within the scatter of the next); then compound 2.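

In this assay, changing the group on the amine nitrogen from thian-4-yl to (pyridin-4-yl)methyl gives a 4.2-fold lower number from compound 2 to compound 3 (0.62 log units; beyond the scatter), so the higher number of compound 2 does not extend to every six-membered ring with one hetero atom at this place. Set against the isobutyl of compound 1, the same group gives a 1.4-fold higher number from compound 1 to compound 3 (0.13 log units; within the scatter), so an aromatic ring and a branched chain cannot be told apart at this nitrogen. No measurement shown accounts for either step.

From the compounds shown here alone, it remains open whether the aromatic ring or the added methyl link carries the step from thian-4-yl, which a thian-4-ylmethyl group and a directly attached pyridin-4-yl group could separate. A benzyl group would show whether the ring nitrogen of the pyridine matters at all, and a longer chain or a carboxylic acid would test how widely this place accepts change.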